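The compounds below may be only part of what the source reports. "The series", "measured", "known", "first", "only" and "open" are said of these compounds alone.

The series shares one core and varies only the aryl group on a saturated ring carbon. Compound 1 `Cc1ccc(C2C(C#N)=C(N)N(c3ccc(S(N)(=O)=O)cc3)C3=C2CCCC3)cc1` gives 30% in a functional assay on Ehrlich cells (Mus musculus) for cytotoxicity, read by trypan blue exclusion, with a stated time of 2 h, tested at 25 ug/mL; a higher number here means a stronger effect of the compound at the concentration tested, a lower number a weaker effect. Compound 2 `N#CC1=C(N)N(c2ccc(S(N)(=O)=O)cc2)C2=C(CCCC2)C1c1ccccc1O` gives 40% in this assay, and compound 3 `COc1ccccc1C1C(C#N)=C(N)N(c2ccc(S(N)(=O)=O)cc2)C2=C1CCCC2` gives 40% in this assay. Compound 3 stands level with compound 2 at the digits printed, the two together the highest of the three numbers. The widest gap among the three is a number 10 percentage points higher from compound 1 to compound 3 (within the scatter). The remaining steps are a number 10 percentage points higher from compound 1 to compound 2 (within the scatter) and no change at the digits printed from compound 2 to compound 3 (within the scatter), so every swap at this saturated ring carbon so far has stayed within the scatter.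

Compound 4 `N#CC1=C(N)N(c2ccc(S(N)(=O)=O)cc2)C2=C(CCCC2)C1c1ccc(Cl)c(Cl)c1` has not yet been measured. Its change from compound 3 is 3,4-dichlorophenyl in place of 2-methoxyphenyl on a saturated ring carbon. Going by the values given here, the steps that bear on it are the earlier aryl swaps at the same saturated ring carbon, a number 10 percentage points higher from compound 1 to compound 3 (within the scatter) and a number 10 percentage points higher from compound 1 to compound 2 (within the scatter), both within the scatter, so no step beyond the scatter in this assay is expected. A 3,4-dichlorophenyl has no measured precedent among these compounds, and the expectation rests only on those swaps. Compound 4 is therefore expected to give 40%, within 25% to 55%. The estimated step is no change at the digits printed from compound 3 to compound 4 (within the scatter).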

Compound 4, a percentage reported as activity, at one concentration (the size of the read-out at that concentration, not a potency): 40%
Compound 4: middle estimate and measured number agree at the digits printed; the measured number falls inside the stated range.
By their numbers in this assay, from the lowest: compounds 1, 2, 3 and 4 (each within the scatter of the next).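

In this assay the new aryl group at the saturated ring carbon gives no change at the digits printed from compound 3 to compound 4 (within the scatter), and the same group read against the other two aryl groups gives no change at the digits printed from compound 2 to compound 4 (within the scatter) and a number 10 percentage points higher from compound 1 to compound 4 (within the scatter). This adds two chlorine atoms to the series and replaces the oxygen of 2-methoxyphenyl, and the count of hydrogen-bond acceptors goes from 1 on the leaving group to 0 on the entering group, yet each of these steps stays within the scatter, so neither the oxygen nor that acceptor is needed at this position for a read-out within the scatter of compounds 2 and 3. No measurement at hand accounts for this outcome.

The compounds shown leave open whether a non-aromatic group at this carbon, such as cyclohexyl or a longer alkyl chain, or an aryl group carrying an amine or a carboxylic acid, would give a step beyond the scatter. With a read-out at a single concentration and a single time, they also leave open how the four compounds compare in potency.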